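This account rests on a few compounds, and the source may have more. Where it says the series, first, only, none or still open, it means among the compounds named here.

Measured in a functional assay on MCF7 cells (Homo sapiens) for antiproliferative activity, read by CCK-8 assay, with a stated time of 72 h; on this read-out higher numbers stand for weaker inhibition of growth and lower numbers for stronger inhibition of growth:
- compound 1 `CCC1C(=O)N(C)c2cnc(-n3ccc4cc(C(=O)NC(C)C)ccc43)nc2N1c1ccn(C)n1`: 8420 nM
- compound 2 `CCCCNC(=O)c1ccc2c(ccn2-c2ncc3c(n2)N(c2ccn(C)n2)C(CC)C(=O)N3C)c1`: 8990 nM
- compound 3 `CCNC(=O)c1ccc2c(ccn2-c2ncc3c(n2)N(c2ccn(C)n2)C(CC)C(=O)N3C)c1`: 13200 nM

The value of compound 3 lies within the usual scatter of both other values, so the three cannot be ranked. These compounds differ only in the group on the amide-type nitrogen: isopropyl in compound 1, butyl in compound 2 and ethyl in compound 3.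

Compound 4 `CCC1C(=O)N(C)c2cnc(-n3ccc4cc(C(=O)NC5CCCC5)ccc43)nc2N1c1ccn(C)n1` has not yet been measured. It carries cyclopentyl in place of ethyl on an amide-type nitrogen and so changes that same group.

Among the measured compounds shown here, three measured steps bear on this change: a 1.1-fold higher number from compound 1 to compound 2 (0.03 log units; within the scatter), a 1.6-fold higher number from compound 1 to compound 3 (0.20 log units; within the scatter) and a 1.5-fold higher number from compound 2 to compound 3 (0.17 log units; within the scatter). All three stay within the scatter. None of these compounds has a ring in that group, so the data leave cyclopentyl itself untested.

No step beyond the scatter is therefore expected in this assay, in either direction. The expected change is a 1.3-fold lower number from compound 3 to compound 4 (0.12 log units; within the scatter) (an estimate only). The estimated value for compound 4 is 10000 nM (expected range 5000 nM to 20000 nM).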

Compound 4, concentration for 50% growth inhibition: "not active" (no number reported)
No number was reported for compound 4; no gap can be computed for the estimate.
By their numbers in this assay, from the lowest: compounds 1, 2 and 3 (each within the scatter of the next).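

In this assay, among the compounds shown here, compound 4 is reported only as "not active", without a number, so no step from compound 1, compound 2 or compound 3 to compound 4 can be read. As far as these compounds go, how far cyclopentyl in place of ethyl shifts growth inhibition stays open. Nothing measured here accounts for this result.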